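Moving the halogen around the aryl piperazine ring

The source may hold more compounds than are shown below. What is called first, only, known or untested is meant among the compounds shown, and "the series" means these compounds.

For the measured compounds named here, two sulfonyl lactam piperazines have numbers so far. Compound 1 `O=C1c2ccccc2S(=O)(=O)N1CCCCCCN1CCN(c2ccccc2Cl)CC1` in an ADME assay on HEK293 cells for displacement of a labelled ligand from 5-hydroxytryptamine receptor 6 (Homo sapiens), read by radioligand binding, with a stated time of 1 h (a lower number here means a stronger inhibitor, a higher number a weaker inhibitor), gives 459 nM. Going by the values given here, compound 2 `O=C1c2ccccc2S(=O)(=O)N1CCCCCCN1CCN(c2ccccc2F)CC1` in this assay gives 1620 nM, the highest of the two numbers; the only step recorded, a 3.5-fold higher number from compound 1 to compound 2 (0.55 log units; beyond the scatter), sets the two apart. Compound 3 `O=C1c2ccccc2S(=O)(=O)N1CCCCCCN1CCN(c2cccc(Cl)c2)CC1` has not yet been measured in this assay. It differs from compound 2 in one place: 3-chlorophenyl in place of 2-fluorophenyl on an amine nitrogen in a ring. Among the compounds with values here, the one measured step that bears on this is the halogen swap at the same position, a 3.5-fold higher number from compound 1 to compound 2 (0.55 log units; beyond the scatter); compound 3 reverses the halogen while also shifting its position on the aryl ring, for which no step is recorded. The return to chloro is expected to bring the number down by about a 3.2-fold lower number from compound 2 to compound 3 (0.51 log units; beyond the scatter) in this assay. Compound 3 is therefore estimated at 500 nM, within the range 150 nM to 1600 nM.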

Compound 3, inhibition constant: 372 nM
Compound 3: the middle estimate sits 1.3-fold (0.13 log units) above what was measured; the measured number falls inside the stated range.
By their numbers in this assay, from the lowest: compounds 3 and 1 (each within the scatter of the next); then compound 2.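

In this assay, 3-chlorophenyl in place of 2-chlorophenyl gives a 1.2-fold lower number from compound 1 to compound 3 (0.09 log units; within the scatter), so moving the chloro on this aryl ring produces no difference that can be read. The change from 2-fluorophenyl to 3-chlorophenyl gives a 4.4-fold lower number from compound 2 to compound 3 (0.64 log units; beyond the scatter), which shows that a lower number than that of compound 2 is reached with chloro at either of the two ring locations tested. Across these three compounds, both chlorophenyl groups stand apart from 2-fluorophenyl, and no compound shown goes against this.

No measured information gives a reason for these differences. Still open, from the compounds shown here alone, are whether fluoro in place of the chloro of compound 3 would raise the number as it does in compound 2, and how a methoxy group, a nitrile or a shorter chain would fare.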